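Methylation of the phenolic oxygen in a chalcone series

The compounds below may be only part of what the source reports. "The series", "measured", "known", "first", "only" and "open" are said of these compounds alone.

Measured compounds:
compound 1 `COc1ccc(/C=C/C(=O)c2ccc(OC)c(OC)c2)cc1O` gives 82.1%
compound 2 `COc1cccc(CCC(=O)c2cccc(O)c2)c1OC` gives 94%
compound 3 `COc1cccc(/C=C/C(=O)c2cccc(O)c2)c1OC` gives 70.8%

All three were tested in an ADME assay on RAW264.7 cells (Mus musculus) for cytotoxicity, read by MTT assay, with a stated time of 24 h, tested at 2.5 ug/mL; a higher number here means a weaker effect of the compound at the concentration tested, a lower number a stronger effect. Among the three numbers, compound 1 stands second highest. Its nearest neighbour is compound 3, whose number lies lower by a gap beyond the usual scatter; the furthest is compound 2, whose number lies higher, again beyond the scatter. Compound 1 therefore sits between the two others, neither the weakest nor the strongest of the set on this read-out.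

Compound 4 `COc1ccc(/C=C/C(=O)c2ccc(OC)c(OC)c2)cc1OC` has not yet been measured. It differs from compound 1 in one place only: methyl in place of hydrogen on an oxygen on an aromatic ring. Cut one bond further out, the change reads hydroxy to methoxy, and the oxygen that carries it is on an aromatic ring whose other neighbours are aromatic carbon. Among the measured compounds shown here, no pair of measured compounds shares this change, so no step of known size is available to lean on.

Compound 4 is expected to give 85%, within 66% to 100%. The step of a number 2.9 percentage points higher from compound 1 to compound 4 (within the scatter) is expected to be small, most likely no larger than the scatter, with the direction left open.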

Compound 4, a percentage reported as activity, at one concentration (the size of the read-out at that concentration, not a potency): 91.9%
Compound 4: the middle estimate sits 6.9 percentage points below what was measured; low and high end bracket the measured number.
By their numbers in this assay, from the lowest: compound 3; then compounds 1, 4 and 2 (each within the scatter of the next, the first and the last beyond it).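

Among the compounds shown here, for the first time, the set gives a measured step for this change: in this assay the step is a number 9.8 percentage points higher from compound 1 to compound 4 (within the scatter) and comes from putting methyl in place of hydrogen on an oxygen on an aromatic ring. Compound 1 and compound 4 therefore cannot be told apart on this read-out, and in this one pair, turning hydroxy into methoxy leaves no difference that stands clear of the usual scatter of repeated measurements. No measurement of any other kind is available that bears on this result, so the step can be stated but not explained.

From the compounds shown here alone, it remains open whether an ethoxy group or a longer chain on the same oxygen, or an amine in place of the hydroxy group, would also leave the read-out within the scatter of compound 1. It is also open whether the same change from hydroxy to methoxy on compound 3 would give a step of similar size, as the single pair shown cannot establish a trend across the series.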